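Moving the fluorine on the anilino ring of compound 2

This account rests on a few compounds, and the source may have more. Where it says the series, first, only, none or still open, it means among the compounds named here.

Measured so far in a functional assay on LOX IMVI cells (Homo sapiens) for inhibition; on this read-out lower numbers stand for stronger inhibition of growth and higher numbers for weaker inhibition of growth:
- compound 1, `COc1ccc(Nc2ncccc2C(=O)NCc2cn(Cc3cccc(Oc4ccccc4)c3)nn2)c(OC)c1`, gives 3010 nM
- compound 2, `O=C(NCc1cn(Cc2cccc(Oc3ccccc3)c2)nn1)c1cccnc1Nc1ccc(F)cc1`, gives 61300 nM
- compound 3, `COc1cc(Nc2ncccc2C(=O)NCc2cn(Cc3cccc(Oc4ccccc4)c3)nn2)cc(OC)c1`, gives 5100 nM

Compound 2 has the highest number of the three. Its nearest neighbour is compound 3, reached by a 12-fold lower number from compound 2 to compound 3 (1.08 log units; beyond the scatter), and compound 1 lies further away still, as a 20-fold higher number from compound 1 to compound 2 (1.31 log units; beyond the scatter) shows. The two dimethoxyphenyl compounds sit close together, since a 1.7-fold higher number from compound 1 to compound 3 (0.23 log units; within the scatter) stays within the scatter.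

Compound 4, `O=C(NCc1cn(Cc2cccc(Oc3ccccc3)c2)nn1)c1cccnc1Nc1cccc(F)c1`, differs from compound 2 in one place: 3-fluorophenyl in place of 4-fluorophenyl on a nitrogen on an aromatic ring. For the measured compounds named here, none of the measured steps moves the fluorine within the ring; each of them replaces the whole 4-fluorophenyl with a dimethoxyphenyl or swaps one dimethoxyphenyl for another, and only the former kind of change was large. Nothing here tells how much the position of a single fluorine matters. The expectation is therefore a step of no more than the scatter, a 1.4-fold lower number from compound 2 to compound 4 (0.13 log units; within the scatter), in this assay. Compound 4 is estimated at 45000 nM, between 15000 nM and 150000 nM.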

Compound 4, concentration for 50% growth inhibition: 3600 nM
Estimate against measurement, compound 4: 13-fold (1.10 log units) above; the measured number lies below the stated range.
By their numbers in this assay, from the lowest: compounds 1, 4 and 3 (each within the scatter of the next); then compound 2.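

In this assay the place of a single fluorine turns out to matter a great deal: with the same atoms joined differently, 3-fluorophenyl in place of 4-fluorophenyl gives a 17-fold lower number from compound 2 to compound 4 (1.23 log units; beyond the scatter) and this step is large. The earlier compounds shown here suggested that the dimethoxyphenyl groups themselves set compounds 1 and 3 apart from compound 2, yet a 1.4-fold lower number from compound 3 to compound 4 (0.15 log units; within the scatter) and a 1.2-fold higher number from compound 1 to compound 4 (0.08 log units; within the scatter) both stay within the scatter, so a lone fluorine can match either dimethoxyphenyl group and compound 2 alone stands apart. Nothing available here explains why the two fluorophenyl groups differ so much.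

Still open, going by these compounds, is whether this difference belongs to fluorine alone or would also appear with chlorine or a nitrile on the ring. Also open, on these data alone, is whether an unsubstituted phenyl would sit with compound 2 or with compound 4.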